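Imidazoline series at the alpha-1 receptor: phenyl on compound 2

The source may report more compounds than this note shows. Statements on the series, on what has been measured and on what is new or still open speak of the compounds shown alone.

Measured so far:
compound 1 `Cc1ccc2c(c1)C=C(CC1CN=C(N)O1)CC2`: 251 nM
compound 2 `C1=NCC(Cc2cc3ccccc3o2)N1`: 2510 nM

In an assay on isolated protein for binding affinity to Adrenergic receptor alpha-1 (Rattus norvegicus), read by radioligand binding, in the presence of a further agent that is not named here (a lower number here means a stronger inhibitor, a higher number a weaker inhibitor), compound 1 gives 251 nM. In this assay compound 2 gives 2510 nM, the highest of the two numbers recorded, with compound 1 the nearest point and its number a clear step lower, beyond the scatter. Within the data shown here, the two compounds share no single-point difference, so their values show only that compound 2 is the weaker of the pair.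

Compound 3 `C1=NCC(Cc2cc3cc(-c4ccccc4)ccc3o2)N1` carries phenyl in place of hydrogen on an aromatic carbon. Among the measured compounds shown here, no pair of measured compounds shows a step of this kind, so there is nothing to calibrate against; the outcome could lie either way. For compound 3 a small gain is expected, a 1.7-fold lower number from compound 2 to compound 3 (0.22 log units; within the scatter), but within a wide band. Compound 3 is estimated at 1500 nM, between 300 nM and 7000 nM.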

Compound 3, inhibition constant: < 3170 nM
Compound 3 was reported as a limit (the forecaster's own chance of this, stated with the estimate: 5%); the middle value is on the limit's open side.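

In this assay no step can be read between compound 2 and compound 3, because compound 3 is reported only as a limit: the limit of < 3170 nM in this assay, at which 1 of the 3 values shown sits.
The compounds shown leave open whether phenyl in place of hydrogen on an aromatic carbon raises or lowers the number, and by how much.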